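The source may hold more compounds than are shown below. What is called first, only, known or untested is meant among the compounds shown, and "the series" means these compounds.

Compound 3 `Cc1cc(Oc2ccc(-c3ccn(CCC(C)C)c(=O)c3C#N)cc2)ccn1` stands highest of the three compounds measured in a functional assay on CHO cells for positive allosteric modulation of metabotropic glutamate receptor 2 (Homo sapiens), read by scintillation counting and GTPgammaS binding, with a stated time of 30 min (on this read-out higher numbers stand for larger maximal responses and lower numbers for smaller maximal responses), where compound 3 gives 266%. Its nearest neighbour is compound 2 `CC(C)CCn1ccc(-c2ccc(Oc3cccnc3)cc2)c(C#N)c1=O`, which in this assay gives 231%, and the furthest is compound 1 `CC(C)CCn1ccc(-c2ccc(Oc3ccccc3)cc2)c(C#N)c1=O`, which in this assay gives 188%. The three steps among them are all large and all beyond the scatter: a number 43 percentage points higher from compound 1 to compound 2 (beyond the scatter), a number 78 percentage points higher from compound 1 to compound 3 (beyond the scatter) and a number 35 percentage points higher from compound 2 to compound 3 (beyond the scatter). Every one of these steps, however, alters only the group on the oxygen on the aromatic ring.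

Compound 4 `Cc1cc(Oc2ccc(-c3ccn(CC4CC4)c(=O)c3C#N)cc2)ccn1` differs from compound 3 in another place: cyclopropyl in place of isobutyl on a saturated chain carbon bound to an aromatic nitrogen. Among the compounds with values here, none of the measured steps touches the chain on the aromatic nitrogen, so no recorded step bears on this change, and the data offer no guide to its direction or size. Within the data shown here, the only anchor is compound 3 itself, which in this assay gives 266%. Compound 4 is therefore expected to stay near that anchor, with a wide band of uncertainty, at an estimated 250% within a range from 190% to 310%. This estimate corresponds to an expected step of a number 16 percentage points lower from compound 3 to compound 4 (beyond the scatter) in this assay.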

Compound 4, largest response reached (Emax), in percent of the reference or control that the assay uses: 199%
Compound 4: middle estimate off by 51 percentage points, on the high side; measured number inside the range.
By their numbers in this assay, from the lowest: compound 1; then compound 4; then compound 2; then compound 3.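

The chain on the aromatic nitrogen proved able to move the maximal response on its own: with the group on the oxygen held constant, cyclopropyl in place of isobutyl gives a number 67 percentage points lower from compound 3 to compound 4 (beyond the scatter) in this assay. Until now, every large step had come from the group on the oxygen, and this result shows that a change at this second place can also produce a large step, here a downward one. It is a single pair in a single background, and nothing given here accounts for the fall in response.

On these data alone, the pair cannot separate the three-membered ring from the change in carbon count, so it remains open whether the fall follows from the ring itself or from the smaller group, a question that a straight butyl chain or a cyclobutyl group on the same saturated chain carbon could address. As far as these compounds go, it also remains open whether the same change would lower the response to a similar degree with the phenyl of compound 1 or the pyridin-3-yl of compound 2 on the oxygen.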